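The source may hold more compounds than are shown below. What is called first, only, known or untested is meant among the compounds shown, and "the series" means these compounds.

Three compounds have been measured in a functional assay for inhibition, with Homo sapiens as the target; a higher number here means a weaker inhibitor, a lower number a stronger inhibitor:

compound 1, `COc1ccc(Nc2nccc(-c3ccncc3)n2)cc1`, 4200 nM
compound 2, `COc1ccc(Nc2nccc(-c3cccs3)n2)cc1`, 3900 nM
compound 3, `CN(C)c1cccc(Nc2nccc(-c3ccncc3)n2)c1`, 3700 nM

Compound 2 is compound 1 with one change, (thiophen-2-yl in place of pyridin-4-yl on an aromatic carbon), and that change made a step of a 1.1-fold lower number from compound 1 to compound 2 (0.03 log units; within the scatter). Compound 3 is built on a different core than compound 1; the difference between the two cores is not broken down here. The three values of compound 1, compound 2 and compound 3 all sit within the scatter of one another in this assay.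

Compound 4, `CN(C)c1cccc(Nc2nccc(-c3cccs3)n2)c1`, has not yet been measured. It is compound 3 with the change (thiophen-2-yl in place of pyridin-4-yl on an aromatic carbon). Among the measured compounds shown here, this is the same kind of change as the one from compound 1 to compound 2, though the surroundings are described a little differently: in compound 1 the place is meta to a group of 9 heavy atoms, in compound 3 it is meta to a large group.

Compound 4 is expected to show a step of a 1.1-fold lower number from compound 3 to compound 4 (0.04 log units; within the scatter) in this assay, set beside the earlier step of a 1.1-fold lower number from compound 1 to compound 2 (0.03 log units; within the scatter), and this expectation rests on that earlier step and on compound 3 giving 3700 nM. The estimate for compound 4 is 3400 nM, with a range from 1700 nM to 7000 nM.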

Compound 4, half-maximal inhibitory concentration: 2400 nM
For compound 4 the middle estimate is 1.4-fold (0.15 log units) above the measured one, and the stated range covers the measured number.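

In this assay, thiophen-2-yl in place of pyridin-4-yl made a step of a 1.5-fold lower number from compound 3 to compound 4 (0.19 log units; within the scatter), and this can be set beside the earlier step on the other core: the same change on two cores in this assay, a 1.1-fold lower number (0.03 log units; within the scatter) from compound 1 to compound 2 and a 1.5-fold lower number (0.19 log units; within the scatter) from compound 3 to compound 4, 1.4-fold (0.16 log units) apart, within the scatter of two such steps. On these two cores, then, the change carries over with no difference that this assay can detect, and on each core the step stays within the usual scatter of repeated measurements. This does not show that the change strengthens inhibition or that the two steps are truly identical, and two cores are too few to predict what it would do on other cores in the series.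

The compounds shown leave open whether a different group in place of pyridin-4-yl, such as a carboxylic acid or a longer alkyl chain, would give a step beyond the scatter. They also leave open whether the change would still carry over on a core bearing a primary amide in place of the groups seen here.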